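Series notes: carboxymethyl to (3-carboxypropyl)carbonyl

The compounds below may be only part of what the source reports. "The series", "measured", "known", "first", "only" and "open" are said of these compounds alone.

Measured so far:
compound 1, `CCCCCCCCCCCCCCC(N)CO`, 7000 nM
compound 2, `CCCCCCCCCCCCCCC(COCc1ccccc1)NCC(=O)O`, 3000 nM

In a functional assay on Jurkat cells (Homo sapiens) for inhibition (on this read-out higher numbers stand for weaker inhibition and lower numbers for stronger inhibition), compound 2 holds the lower of the two numbers; the number of compound 1 lies beyond the scatter above it. Compound 1 and compound 2 differ in more than one place, so only their two values are known. Compound 3, `CCCCCCCCCCCCCCC(COCc1ccccc1)NC(=O)CCCC(=O)O`, carries the change ((3-carboxypropyl)carbonyl in place of carboxymethyl on an amine nitrogen). Among the measured compounds shown here, no single-point step has been measured in this set, so the expectation rests on the change alone: a small upward step in this assay, close to the scatter, is expected, namely a 1.7-fold higher number from compound 2 to compound 3 (0.22 log units; within the scatter). Compound 3 is estimated at 5000 nM, within 1500 nM to 20000 nM.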

Compound 3, half-maximal inhibitory concentration: > 50000 nM
Compound 3 was reported as a limit; the forecaster's own chance of this, stated with the estimate: 10%; at least 10-fold (1.00 log units) between middle value and limit.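

In this assay, the group on the amine nitrogen clearly matters: (3-carboxypropyl)carbonyl in place of carboxymethyl gives an at least 16-fold higher number from compound 2 to compound 3 (1.22 log units; beyond the scatter). Among the compounds shown here, the earlier compounds differ in more than one place, so this is the first single-place step. Compound 3 is a limit and not a number, so the full size of the step stays unknown: the limit of > 50000 nM in this assay, at which 1 of the 3 values shown sits.

The compounds shown leave open whether the carbonyl on the nitrogen or the longer chain carries this change. A secondary amine bearing a 3-carboxypropyl chain would separate the two.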